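The source may report more compounds than this note shows. Statements on the series, on what has been measured and on what is new or still open speak of the compounds shown alone.

Measured compounds, in an assay on HEK293 cells for inhibition of N-acylethanolamine-hydrolyzing acid amidase (Homo sapiens), read by fluorescence, with stated times of 10 min and 50 min; a lower number here means a stronger inhibitor, a higher number a weaker inhibitor:
compound 1, `CCCc1ccc(COC(=O)N[C@H]2CNC2=O)cc1`, gives 52 nM;
compound 2, `CC(C)(C)c1ccc(COC(=O)N[C@H]2CNC2=O)cc1`, gives 310 nM;
compound 3, `O=C(N[C@H]1CNC1=O)OCc1ccc2c(c1)CCCC2`, gives 140 nM.

Compound 2 stands at the highest number of the three. Compound 1 and compound 2 differ only at the aromatic carbon that carries the alkyl group, and the step of a 6.0-fold higher number from compound 1 to compound 2 (0.78 log units; beyond the scatter) lies beyond the scatter. Among the compounds with values here, no single-change step joins compound 2 and compound 3; their two values show compound 3 at the lower number, with the gap beyond the scatter.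

Compound 4, `O=C(N[C@H]1CNC1=O)OCc1ccc(-c2cccnc2)cc1`, is not yet measured. It differs from compound 2 by pyridin-3-yl in place of tert-butyl on an aromatic carbon. Within the data shown here, the only measured step that touches this carbon is a 6.0-fold higher number from compound 1 to compound 2 (0.78 log units; beyond the scatter), where a bulkier saturated group in place of a straight chain gave the higher number; no measured step exchanges an alkyl group for an aromatic ring at this position, so the direction of the present change rests on that one step and on compound 2 being the highest number of the set. A move back toward the lower numbers of compound 1 and compound 3 is expected, of modest size and with wide uncertainty, as a 2.6-fold lower number from compound 2 to compound 4 (0.41 log units; beyond the scatter). For compound 4 in this assay the estimate is 120 nM, within 30 nM to 500 nM.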

Compound 4, half-maximal inhibitory concentration: 8110 nM
Beside the measured number, compound 4's estimate is 68-fold (1.83 log units) below it, and the stated range ends below it.
By their numbers in this assay, from the lowest: compound 1; then compound 3; then compound 2; then compound 4.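

Across the alkyl groups at this aromatic carbon, the numbers in this assay had stayed in the range set by compound 1 and compound 2. An aromatic ring at the same carbon moves the series into a different range: pyridin-3-yl in place of tert-butyl gives a 26-fold higher number from compound 2 to compound 4 (1.42 log units; beyond the scatter), a large step, so the highest number among the alkyl compounds was no floor for this position. Measured against the straight chain, the change is larger still, at a 160-fold higher number from compound 1 to compound 4 (2.19 log units; beyond the scatter), and this position therefore responds far more strongly to exchanging an alkyl group for pyridin-3-yl than the alkyl compounds alone could show; nothing at hand accounts for the size of either step.

With a single aromatic example, the ring itself and its nitrogen cannot be told apart, and an unsubstituted phenyl ring at this carbon, or pyridin-2-yl or pyridin-4-yl, would be needed to separate them. Also open, going by these compounds, is whether a saturated ring such as cyclohexyl or piperidine, or a longer chain such as butyl, stays with the alkyl compounds or follows compound 4.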